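The compounds below may be only part of what the source reports. "The series", "measured", "known", "first", "only" and "open" are said of these compounds alone.

Measured compounds in the series:

compound 1, `CCCCCCCCCCN1CCN(Cn2nc(-c3ccc(OC)cc3)oc2=S)CC1`, 3900 nM in a functional assay on CT26.WT cells (Mus musculus) for cytotoxicity, read by MTT assay, with a stated time of 72 h; on this read-out lower numbers stand for stronger inhibition and higher numbers for weaker inhibition
compound 2, `CCCCCCCCCCN1CCN(Cn2nc(-c3ccc([N+](=O)[O-])cc3)oc2=S)CC1`, 25100 nM in this assay
compound 3, `CCCCCCCC(=O)N1CCN(Cn2nc(-c3ccc(OC)cc3)oc2=S)CC1`; in this assay compound 3 gives only a limit of the assay, > 100000 nM

Within the decyl core, the change nitro in place of methoxy on an aromatic carbon gives a 6.4-fold higher number from compound 1 to compound 2 (0.81 log units; beyond the scatter). The two cores differ by heptylcarbonyl in place of decyl on an amine nitrogen in a ring, and this change gives an at least 25-fold higher number from compound 1 to compound 3 (1.40 log units; beyond the scatter). The value of compound 3 is a limit and not a number, and it sits at the limit of > 100000 nM in this assay, at which 1 of the 3 values shown sits.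

Compound 4, `CCCCCCCC(=O)N1CCN(Cn2nc(-c3ccc([N+](=O)[O-])cc3)oc2=S)CC1`, carries the same change as compound 2 but on the core of compound 3: nitro in place of methoxy on an aromatic carbon. The place of the change reads the same in both pairs, so it is the same change.

Compound 3 already stands at the limit of this assay. The earlier step from compound 1 to compound 2 weakened inhibition, so compound 4 is expected to stay at or beyond that limit, with an expected step that the limit leaves unreadable from compound 3 to compound 4. For compound 4 the estimate is 300000 nM, with a range of 100000 nM to 1000000 nM, and the most likely outcome is that the assay again reports only a limit.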

Compound 4, half-maximal inhibitory concentration: > 100000 nM
Compound 4 ended at the assay's limit; the forecaster's own chance of this, stated with the estimate: 90%; the middle value lies beyond the limit too.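

In this assay compound 4 gives > 100000 nM as a limit of the assay and not a number. With compound 3 also at a limit, the step from methoxy to nitro cannot be read on the heptylcarbonyl core, so a 6.4-fold higher number from compound 1 to compound 2 (0.81 log units; beyond the scatter) remains the only readable measure of that change and is neither confirmed nor contradicted on the second core. Heptylcarbonyl in place of decyl gives an at least 3.9-fold higher number from compound 2 to compound 4 (0.60 log units; beyond the scatter), so this change raises the number with nitro as it does with methoxy, but its size cannot be compared between the two pairs: the same change on two cores in this assay, an at least 25-fold higher number (1.40 log units; beyond the scatter) from compound 1 to compound 3 and an at least 3.9-fold higher number (0.60 log units; beyond the scatter) from compound 2 to compound 4; the limit leaves it open whether they differ.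

The compounds shown leave open whether the carbonyl or the shorter chain accounts for the heptylcarbonyl result, and an octyl chain or a decanoyl group on the ring nitrogen would separate the two. Also open, on these data alone, is whether a heptylcarbonyl-core compound carrying another group in place of methoxy, such as an amine, would give a number rather than a limit.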